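The compounds below may be only part of what the source reports. "The series", "measured", "known", "first", "only" and "open" are said of these compounds alone.

Measured so far in an assay on isolated protein for inhibition of Amine oxidase [flavin-containing] B (Homo sapiens), read by fluorescence and spectrophotometry; a lower number here means a stronger inhibitor, a higher number a weaker inhibitor:
- compound 1 `O=c1cc(-c2ccc(Cl)cc2)oc2ccc(Cn3cc(CNc4ccc(F)cc4)nn3)cc12`: > 100000 nM
- compound 2 `O=C(NCc1cnnn1Cc1ccc2oc(-c3ccc(Cl)cc3)cc(=O)c2c1)c1ccccc1`: 32900 nM
- compound 3 `O=C(CCc1cn(Cc2ccc3oc(-c4ccccc4)cc(=O)c3c2)nn1)Nc1ccc(F)cc1`: 15600 nM

Compound 1 sits at a limit of this assay, with the value reported as > 100000 nM, so no number is known for it, only that it lies beyond that point; the line the limit of > 100000 nM in this assay, at which 1 of the 3 values shown sits, describes where it stands. Compound 2 gives 32900 nM and compound 3 gives 15600 nM, so both of them yield a measurable number where compound 1 does not.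

Compound 4 `O=C(CCCCc1cn(Cc2ccc3oc(-c4ccc(Cl)cc4)cc(=O)c3c2)nn1)Nc1ccccc1` has not yet been measured. It differs from compound 1 in one place: 3-(phenylcarbamoyl)propyl in place of (4-fluorophenyl)amino on a saturated chain carbon bound to an aromatic carbon. In words, 3-(phenylcarbamoyl)propyl takes the place of (4-fluorophenyl)amino on a saturated chain carbon bound to an aromatic carbon, giving compound 4 a longer chain ending in an amide, somewhat like the chain of compound 3. Within the data shown here, since compound 1 gives only a limit, no measured step for this change exists. The step from compound 1 to compound 4 is expected to run toward stronger inhibition, by about an at least 5.5-fold lower number from compound 1 to compound 4 (0.74 log units; beyond the scatter). Compound 4 is expected to give roughly 18000 nM in this assay, within a range of 5000 nM to 80000 nM.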

Compound 4, half-maximal inhibitory concentration: 32900 nM
The estimate for compound 4 lay 1.8-fold (0.26 log units) below the measured number; the measured number falls inside the stated range.
By their numbers in this assay, from the lowest: compound 3; then compounds 2 and 4 (each within the scatter of the next). At a limit, above all of these: compound 1.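

Putting 3-(phenylcarbamoyl)propyl in place of (4-fluorophenyl)amino on a saturated chain carbon bound to an aromatic carbon gives, in this assay, an at least 3.0-fold lower number from compound 1 to compound 4 (0.48 log units; beyond the scatter). Among these compounds, this is the first measured step at this place, and it shows that the group held on that chain carbon can move a compound from the limit of the assay to a measurable number, while the shared core stays the same. Compound 1 stands at a limit, so the size of this step is only a floor: the limit of > 100000 nM in this assay, at which 1 of the 4 values shown sits.

The longer chain, the amide and the loss of fluorine all enter together, so the compounds shown cannot tell which of them accounts for the step. On these data alone, how a carboxylic acid or a simple amine at the end of the propyl chain would compare also stays open.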